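Dimethylamino in place of hydroxy: a step still unmeasured

This account rests on a few compounds, and the source may have more. Where it says the series, first, only, none or still open, it means among the compounds named here.

In a functional assay on ACHN cells (Homo sapiens) for inhibition (a higher number here means a weaker inhibitor of growth, a lower number a stronger inhibitor of growth), compound 1 (`NS(=O)(=O)c1ccc(/C=C/c2ccc(F)cc2)cc1`) gives 2970 nM, and compound 2 (`NS(=O)(=O)c1ccc(/C=C/c2ccc(O)cc2)cc1`) gives 2280 nM. Among the compounds with values here, compound 2 therefore stands level with compound 1, the only other compound measured, and neither number stands apart from the other. Compound 3 (`CN(C)c1ccc(/C=C/c2ccc(S(N)(=O)=O)cc2)cc1`) remains unmeasured. It differs from compound 2 by dimethylamino in place of hydroxy on an aromatic carbon, with dimethylamino in place of hydroxy on an aromatic carbon, para to a large group. Within the data shown here, one measured step bears on this carbon, the exchange of fluoro for hydroxy: a 1.3-fold lower number from compound 1 to compound 2 (0.11 log units; within the scatter), which lies within the scatter. From the compounds shown here alone, on that single step, no shift beyond the scatter is expected in either direction, although dimethylamino itself is untested and the evidence is thin. The estimated step is a 1.1-fold higher number from compound 2 to compound 3 (0.04 log units; within the scatter), which stays within the scatter. For compound 3 the expected value is 2500 nM, with an estimated range of 800 nM to 7000 nM.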

Compound 3, concentration for 50% growth inhibition: 13600 nM
Compound 3: middle estimate off by 5.4-fold (0.74 log units), on the low side; measured number above the stated range.
By their numbers in this assay, from the lowest: compounds 2 and 1 (each within the scatter of the next); then compound 3.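

In this assay, the aromatic carbon para to a large group proves sensitive to what it carries. Fluoro and hydroxy could not be told apart there, whereas dimethylamino in place of hydroxy gives a 6.0-fold higher number from compound 2 to compound 3 (0.78 log units; beyond the scatter), and dimethylamino in place of fluoro gives a 4.6-fold higher number from compound 1 to compound 3 (0.66 log units; beyond the scatter). Growth inhibition at this position therefore weakens with dimethylamino, and nothing available explains why.

The compounds shown leave open whether the weakening goes with the two carbons that dimethylamino brings or with its nitrogen, and whether its lack of a hydrogen-bond donor plays any part. A primary amine or a methylamino group on the same carbon would begin to separate these, and a methoxy group would show what an oxygen without a hydrogen-bond donor does there.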